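Swapping a chlorophenyl for methyl on the shared core

The source may report more compounds than this note shows. Statements on the series, on what has been measured and on what is new or still open speak of the compounds shown alone.

Of the compounds shown here, three built on one shared core have been tested in a functional assay on the whole organism for inhibition, with Mythimna separata as the target, with a stated time of 5 days; a higher number here means that more compound is needed for the effect, a lower number that less compound is needed. Compound 1 `CC(C)(C)n1ncc(OCc2nnc(-c3ccccc3Cl)o2)c(Cl)c1=O` carries a 2-chlorophenyl on its five-membered aromatic ring with 2 nitrogen and 1 oxygen; in this assay compound 1 gives 61.2 ug/mL. For the measured compounds named here, compound 2 `CC(C)(C)n1ncc(OCc2nnc(-c3cc(F)c(Cl)cc3Cl)s2)c(Cl)c1=O` gives 67.1 ug/mL in this assay, a number that sits within the scatter of the one for compound 1, so the two cannot be told apart. Compound 3 `Cc1cc(C)cc(-c2nnc(COc3cnn(C(C)(C)C)c(=O)c3Cl)s2)c1` reaches only a limit of the assay, > 300 ug/mL, and no number.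

Going by the values given here, the one measured step that changes the aryl group, an at least 4.4-fold higher number from compound 2 to compound 3 (0.65 log units; beyond the scatter), points toward the limit of > 300 ug/mL in this assay, at which 1 of the 3 values shown sits, and shows that this ring is not easily altered without loss.

Compound 4 `Cc1nnc(COc2cnn(C(C)(C)C)c(=O)c2Cl)o1` differs from compound 1 in a single place: methyl in place of 2-chlorophenyl on an aromatic carbon. Among the compounds with values here, this removes the whole aromatic ring rather than redecorating it, a larger change than the one between compound 2 and compound 3. Since that smaller change already gave an at least 4.4-fold higher number from compound 2 to compound 3 (0.65 log units; beyond the scatter), an increase in the number of similar or larger size is expected here, with a real chance that only a limit is reported. Compound 4 is therefore estimated at 220 ug/mL, with a range from 70 ug/mL to 600 ug/mL, meaning an expected step of a 3.6-fold higher number from compound 1 to compound 4 (0.56 log units; beyond the scatter).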

Compound 4, half-maximal effective concentration: > 300 ug/mL
Compound 4: a limit, no number; the forecaster's own chance of this, stated with the estimate: 40%; middle value at least 1.3-fold (0.13 log units) from the limit.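

In this assay, methyl in place of 2-chlorophenyl on this aromatic carbon gives an at least 4.9-fold higher number from compound 1 to compound 4 (0.69 log units; beyond the scatter). The earlier step exchanged one substituted phenyl for another, whereas this one removes the aromatic ring altogether, and the loss shows that methyl cannot stand in for the 2-chlorophenyl at this place on the core of compound 1; a phenyl ring alone is still no guarantee of a measured number, since compound 3 carries one and stays at a limit. Compound 4 also gives a limit rather than a number, so the true size of the step stays unknown, and the set now contains as many limits as numbers: the limit of > 300 ug/mL in this assay, at which 2 of the 4 values shown sit.

What the compounds shown leave open is whether the aromatic ring itself matters or whether another carbon group would serve as well, for instance a cyclohexyl ring or a benzyl group at this place. An unsubstituted phenyl would help to separate the part played by the chlorine from that of the ring, and what it would give remains an open question.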